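The source may hold more compounds than are shown below. What is called first, only, known or untested is meant among the compounds shown, and "the series" means these compounds.

Measured so far in an ADME assay on K562 cells (Homo sapiens) for cytotoxicity, with a stated time of 72 h; a higher number here means a weaker inhibitor, a lower number a stronger inhibitor:
Compound 1 `COc1ccc(CNc2ncnc3c2ncn3C2CCCCO2)cc1`: > 100000 nM (a limit)
Compound 2 `COc1ccccc1CNc1ncnc2c1ncn2C1CCCO1`: > 100000 nM (a limit)
Compound 3 `COc1cccc(CNc2ncnc3c2ncn3C2CCCO2)c1`: > 100000 nM (a limit)

No number exists yet in this assay, as the limit of > 100000 nM in this assay, at which 3 of the 3 values shown sit, shows. Compound 3 stands only at its limit of > 100000 nM. Compound 4 `COc1ccc(CNc2ncnc3c2ncn3C2CCCO2)cc1` has 4-methoxyphenyl in place of 3-methoxyphenyl on a saturated chain carbon bound to a nitrogen on an aromatic ring. For the measured compounds named here, the one measured step that bears on this is a step that the two limits leave unreadable from compound 2 to compound 3, made at the same place, and its size cannot be read. The expectation therefore rests on compound 3 and its limit of > 100000 nM. No change beyond the scatter is expected, in either direction, and the expected step is a number no higher from compound 3 to compound 4 (the limit leaves the size open). Compound 4 is estimated at 100000 nM, with an expected range of 50000 nM to 200000 nM.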

Compound 4, half-maximal inhibitory concentration: > 100000 nM
Compound 4: a limit, no number; the forecaster's own chance of this, stated with the estimate: 85%; the middle value sits exactly at the limit.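

For the compounds shown here, compound 4 gives a limit and not a number, so no step from compound 1, compound 2 or compound 3 to compound 4 can be read: the limit of > 100000 nM in this assay, at which 4 of the 4 values shown sit. The compounds shown leave open whether 2-methoxyphenyl, 3-methoxyphenyl, 4-methoxyphenyl, oxolan-2-yl or oxan-2-yl makes any difference to the half-maximal inhibitory concentration.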